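Halogen swap on the pendant aryl ring of compound 3

A few compounds are considered here, and "the series" means these few. Any claim that something is new, unique, unknown or untested is made for them only; others in the source may bear on it.

Measured compounds in a functional assay on HeLa cells (Homo sapiens) for cytotoxicity, with a stated time of 72 h; on this read-out lower numbers stand for stronger inhibition and higher numbers for weaker inhibition:
compound 1, `Clc1ccc(Cc2nn3cc(-c4ccc(Br)cc4)nc3s2)cc1`, reports only a limit, > 250000 nM
compound 2, `Clc1ccc(Cc2nn3c(Br)c(-c4ccc(Br)cc4)nc3s2)cc1`, gives 188000 nM
compound 3, `N#CSc1c(-c2ccc(F)cc2)nc2sc(Cc3ccc(Cl)cc3)nn12`, gives 20000 nM

Within the data shown here, the only single-point step measured so far is an at least 1.3-fold lower number from compound 1 to compound 2 (0.12 log units; that floor lies within the scatter); it runs toward a lower number but starts from the limit of > 250000 nM in this assay, at which 1 of the 3 values shown sits, so its true size is not known. Among the measured compounds shown here, compound 3 holds the lowest of the two actual numbers in this assay, and the nearest number, that of compound 2, lies above it by a gap beyond the scatter; compound 2 and compound 3 differ in more than one place, so no single step connects them.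

Compound 4, `N#CSc1c(-c2ccc(Br)cc2)nc2sc(Cc3ccc(Cl)cc3)nn12`, is not yet measured. It differs from compound 3 in one place: bromo in place of fluoro on an aromatic carbon. For the measured compounds named here, no measured step carries this change; the one measured step, from hydrogen to bromo on the core, lies within the scatter in this assay. The step of a 1.3-fold lower number from compound 3 to compound 4 (0.10 log units; within the scatter) is therefore expected to stay within the scatter, in no firm direction. For compound 4 the expected value in this assay is 16000 nM, with a range from 5000 nM to 50000 nM.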

Compound 4, half-maximal inhibitory concentration: 22000 nM
Compound 4: the middle estimate sits 1.4-fold (0.14 log units) below what was measured; measured number inside the range.
By their numbers in this assay, from the lowest: compounds 3 and 4 (each within the scatter of the next); then compound 2. At a limit, above all of these: compound 1.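

In this assay, among these compounds, the change from 4-fluorophenyl to 4-bromophenyl gives a 1.1-fold higher number from compound 3 to compound 4 (0.04 log units; within the scatter), so this place on the six-membered aromatic ring shows no readable difference between the two halogens, a change that no earlier step covered. With the 4-bromophenyl group held fixed, cyanosulfanyl in place of bromo on the shared core gives an 8.5-fold lower number from compound 2 to compound 4 (0.93 log units; beyond the scatter), the first single-place step in the series that is a firm number beyond the scatter, and among these compounds it places the movement in this assay on the core substituent and not on the aryl halogen. Cyanosulfanyl in place of hydrogen gives an at least 11-fold lower number from compound 1 to compound 4 (1.05 log units; beyond the scatter), but this reads only as a floor, as its starting point is a limit: the limit of > 250000 nM in this assay, at which 1 of the 4 values shown sits.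

Going by these compounds, it remains open whether the lower numbers belong to cyanosulfanyl in particular, or whether a plain nitrile or a methylsulfanyl group on the same aromatic carbon would match them. On these data alone, it is also open whether the aryl place stays this insensitive beyond the two halogens, for example with an amine or a carboxylic acid in place of bromo.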